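This account rests on a few compounds, and the source may have more. Where it says the series, first, only, none or still open, it means among the compounds named here.

Of the compounds shown here, three sharing one core have been measured in an assay on isolated protein for inhibition of leukotriene B4 receptor 1 (Homo sapiens), tested at 10 uM; a lower number here means less inhibition, a higher number more inhibition at the concentration tested (going by the name of the read-out). Compound 1 `CC(=O)c1ccc(OCCCCC#N)cc1O` gives 0%. Compound 2 `CCCCc1cc(C(C)=O)c(O)cc1OCCCCC#N` gives 41%, and compound 3 `CC(=O)c1cc(CC(C)O)c(OCCCCC#N)cc1O` gives 10%. Compound 3 thus stands second highest of the three: its value and that of compound 1 lie within the usual scatter of each other, while a number 31 percentage points lower from compound 2 to compound 3 (beyond the scatter) is a large step. Compound 4 `CC(=O)c1cc(C=O)c(OCCCCC#N)cc1O` has not yet been measured; it differs from compound 3 by formyl in place of 2-hydroxypropyl on an aromatic carbon. Within the data shown here, two measured steps bear on this change. a number 10 percentage points higher from compound 1 to compound 3 (within the scatter) shows that a 2-hydroxypropyl group barely moves the number, whereas a number 41 percentage points higher from compound 1 to compound 2 (beyond the scatter) shows that a butyl group raises it strongly, and a number 31 percentage points lower from compound 2 to compound 3 (beyond the scatter) shows the drop when 1-hydroxyethyl stands in place of propyl. Among the measured compounds shown here, no measured compound carries a formyl group, so its effect is untested. Compound 4 is therefore expected to land low, and the estimated a number 2 percentage points lower from compound 3 to compound 4 (within the scatter) should stay within the scatter. The estimate for compound 4 in this assay is 8%, with a range from 0% to 25%.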

Compound 4, a percentage reported as inhibition, at one concentration (the size of the read-out at that concentration, not a potency): 6%
Estimate against measurement, compound 4: 2 percentage points above, and the stated range covers the measured number.
By their numbers in this assay, from the lowest: compounds 1, 4 and 3 (each within the scatter of the next); then compound 2.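

In this assay, replacing 2-hydroxypropyl with formyl, a group that carries no hydrogen-bond donor, gives a step within the scatter (a number 4 percentage points lower from compound 3 to compound 4 (within the scatter)). Formyl in place of hydrogen also stays within the scatter (a number 6 percentage points higher from compound 1 to compound 4 (within the scatter)), so neither of these two quite different oxygen-bearing groups can be told apart from the unsubstituted compound, while butyl remains clearly separate (a number 35 percentage points lower from compound 2 to compound 4 (beyond the scatter)). No measurement at hand explains why butyl stands apart from formyl.

As far as these compounds go, it remains open whether the high value depends on the plain carbon chain, since a longer chain, such as hexyl, would test whether the number keeps rising. An amine or a carboxylic acid on the same aromatic carbon would show whether groups of another kind also stay near the low values.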